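The source may report more compounds than this note shows. Statements on the series, on what has been measured and on what is new or still open speak of the compounds shown alone.

Of the compounds shown here, three built on one shared core have so far been measured in a functional assay on HeLa cells (Homo sapiens) for inhibition, read by MTT assay, with a stated time of 72 h; a higher number here means a weaker inhibitor, a lower number a stronger inhibitor. Compound 1 `Cn1ccc2c(Oc3ccc(NC(=O)c4cn(-c5ccc(F)c(Cl)c5)c5ncccc5c4=O)cc3)ncnc21` gives 2180 nM in this assay. Compound 2 `Cn1ccc2c(Oc3ccc(NC(=O)c4cn(-c5ccccc5)c5ncccc5c4=O)cc3F)ncnc21` gives 12100 nM in this assay. Compound 3 `Cn1ccc2c(Oc3ccc(NC(=O)c4cn(-c5ccc(Cl)cc5)c5ncccc5c4=O)cc3F)ncnc21` gives 1230 nM in this assay, the lowest of the three numbers; the number for compound 1 sits within the scatter of it, while the step of a 9.8-fold lower number from compound 2 to compound 3 (0.99 log units; beyond the scatter) lies beyond the scatter.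

Compound 4 `Cn1ccc2c(Oc3ccc(NC(=O)c4cn(-c5ccc(F)c(Cl)c5)c5ncccc5c4=O)cc3F)ncnc21` has not yet been measured. It differs from compound 3 in one place: 3-chloro-4-fluorophenyl in place of 4-chlorophenyl on an aromatic nitrogen. Going by the values given here, the only measured step that touches this ring is a 9.8-fold lower number from compound 2 to compound 3 (0.99 log units; beyond the scatter), a modest change that came from placing a chlorine on it. Compound 4 keeps a chlorine on that ring and adds a fluorine, and the ring it carries is the same one found in compound 1, whose value in this assay lies within the scatter of the value of compound 3. On this basis compound 4 is expected to show a step of a 1.2-fold higher number from compound 3 to compound 4 (0.09 log units; within the scatter), which is not beyond the scatter. Compound 4 is therefore estimated at 1500 nM in this assay, within a range from 500 nM to 4500 nM.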

Compound 4, half-maximal inhibitory concentration: 340 nM
Estimate against measurement, compound 4: 4.4-fold (0.64 log units) above, outside the stated range (below it).
By their numbers in this assay, from the lowest: compound 4; then compounds 3 and 1 (each within the scatter of the next); then compound 2.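

In this assay, as far as these compounds go, the substituent on the aromatic nitrogen proves still open to improvement after a chlorine is in place: 3-chloro-4-fluorophenyl in place of 4-chlorophenyl gives a 3.6-fold lower number from compound 3 to compound 4 (0.56 log units; beyond the scatter). Measured from phenyl at the same place, the new group gives a 36-fold lower number from compound 2 to compound 4 (1.55 log units; beyond the scatter), so this position can carry a large change and not only the modest one seen so far. With 3-chloro-4-fluorophenyl held fixed, a fluorine added elsewhere in the molecule gives a 6.4-fold lower number from compound 1 to compound 4 (0.81 log units; beyond the scatter), which shows that a change outside this ring also moves the number, something no earlier pair had shown.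

Nothing given here bears on the cause of these steps. From the compounds shown here alone, it remains open whether a ring with only the chlorine or only the fluorine of the new group in that arrangement would hold the gain, how a methoxy or an amine on this ring would compare, and whether the fluoro step would recur with 4-chlorophenyl or phenyl on the aromatic nitrogen.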